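Aroyl variation at the thiourea carbonyl in one core

A few compounds are considered here, and "the series" means these few. Any claim that something is new, unique, unknown or untested is made for them only; others in the source may bear on it.

Three compounds share one core and differ only in the group on the carbonyl carbon. In an ADME assay on Huh-7 cells (Homo sapiens) for cytotoxicity (on this read-out lower numbers stand for stronger inhibition and higher numbers for weaker inhibition), compound 1 `CN(c1cc2ncc(=O)[nH]c2cc1NC(=S)NC(=O)c1ccc(F)cc1)C1CCCCC1` gives 11400 nM, compound 2 `CN(c1cc2ncc(=O)[nH]c2cc1NC(=S)NC(=O)c1cccc(C(F)(F)F)c1)C1CCCCC1` gives 31500 nM and compound 3 `CN(c1cc2ncc(=O)[nH]c2cc1NC(=S)NC(=O)/C=C/c1ccccc1)C1CCCCC1` gives 11000 nM. Compound 1 stands second highest of the three numbers: its nearest neighbour is compound 3 a 1.0-fold lower number from compound 1 to compound 3 (0.02 log units; within the scatter), its furthest is compound 2 a 2.8-fold higher number from compound 1 to compound 2 (0.44 log units; beyond the scatter); between the other two, a 2.9-fold lower number from compound 2 to compound 3 (0.46 log units; beyond the scatter).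

Compound 4 `CN(c1cc2ncc(=O)[nH]c2cc1NC(=S)NC(=O)c1cccc2ccccc12)C1CCCCC1` is not yet measured. It differs from compound 1 as follows: naphthalen-1-yl in place of 4-fluorophenyl on a carbonyl carbon. The measured steps that bear on it are changes of the same aroyl group, both modest at most: one raised the number beyond the scatter, one stayed within it. Within the data shown here, no measured step contains a naphthalen-1-yl group, so the expectation is loose. Compound 4 is expected to show a step of a 1.4-fold higher number from compound 1 to compound 4 (0.15 log units; within the scatter) in this assay, a small rise at most, possibly none beyond the scatter. The estimate for compound 4 is 16000 nM, within 6000 nM to 45000 nM.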

Compound 4, half-maximal inhibitory concentration: 9980 nM
The estimate for compound 4 lay 1.6-fold (0.20 log units) above the measured number; low and high end bracket the measured number.
By their numbers in this assay, from the lowest: compounds 4, 3 and 1 (each within the scatter of the next); then compound 2.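

In this assay, naphthalen-1-yl on the carbonyl carbon gives no step beyond the scatter, either against 4-fluorophenyl, a 1.1-fold lower number from compound 1 to compound 4 (0.06 log units; within the scatter), or against 2-phenylethenyl, a 1.1-fold lower number from compound 3 to compound 4 (0.04 log units; within the scatter), so a second six-membered aromatic ring of carbon only, with the fluorine gone, leaves the number in place. Compound 2 stays apart, a 3.2-fold lower number from compound 2 to compound 4 (0.50 log units; beyond the scatter), and among these four compounds only the 3-(trifluoromethyl)phenyl group sets a number off from the rest. No supporting data bear on why that group alone stands apart.

The compounds shown carry only aromatic or phenyl-bearing groups on the carbonyl carbon, so it remains open how a saturated group such as cyclohexyl or a longer alkyl chain would read here. Also open, going by these compounds, is whether an amine or a carboxylic acid on the phenyl ring would move the number beyond the scatter.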